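Trimming the Amine on a Fused Adenosine Antagonist Core

The source may hold more compounds than are shown below. What is called first, only, known or untested is meant among the compounds shown, and "the series" means these compounds.

compound 1 `O=C(Nc1ncc(C(=O)O)c2nc(-c3ccco3)nn12)NC1CCCCC1`: > 30000 nM
compound 2 `CCOC(=O)c1cnc(NC2CCCC2)n2nc(-c3ccco3)nc12`: 4620 nM

In a functional assay on CHO cells for antagonist activity at adenosine receptor A2b (Homo sapiens) (a lower number here means a stronger inhibitor, a higher number a weaker inhibitor), compound 2 gives 4620 nM. Compound 1 reaches only > 30000 nM, which is a limit of the measurement rather than a number. Compound 2 is thus the sole real number shown here.

Compound 3 `CCOC(=O)c1cnc(N(C)C)n2nc(-c3ccco3)nc12` has not yet been measured. It differs from compound 2 by dimethylamino in place of cyclopentylamino on an aromatic carbon. No measured step of this kind is shown. The step of a 3.2-fold higher number from compound 2 to compound 3 (0.51 log units; beyond the scatter) is expected to lean toward weaker inhibition in this assay, and possibly by more than usual scatter. Compound 3 is estimated at 15000 nM, within a range from 4000 nM to 50000 nM.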

Compound 3, inhibition constant: > 10000 nM
Compound 3 was reported as a limit (the forecaster's own chance of this, stated with the estimate: 35%); the middle value lies beyond the limit too.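

At this aromatic carbon, para to the ethoxycarbonyl group, replacing cyclopentylamino with dimethylamino gives an at least 2.1-fold higher number from compound 2 to compound 3 (0.33 log units; beyond the scatter), so this position does not accept the change without a loss in this assay. Compound 3 gives > 10000 nM, which is a limit and not a number. The change removes both the ring and the amine hydrogen-bond donor, and this single step cannot separate the two.

From the compounds shown here alone, the true size of the loss stays open. So does the result for methylamino at this carbon, which would keep the donor but lack the ring.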